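Bromo for fluoro on the phenoxy ring: cytotoxicity outlook

A few compounds are considered here, and "the series" means these few. Any claim that something is new, unique, unknown or untested is made for them only; others in the source may bear on it.

Compounds measured so far, with their values in a functional assay on cells (Homo sapiens) for cytotoxicity; on this read-out higher numbers stand for lower toxicity in this test and lower numbers for higher toxicity in this test:
compound 1, `O=C1N(CCCCCCOc2ccc(Cl)cc2)CCN1c1cccnc1`, > 25000 nM;
compound 2, `O=C1N(CCCCCCCOc2ccc(Cl)cc2)CCN1c1cccnc1`, > 25000 nM;
compound 3, `O=C1N(CCCCCCOc2ccc(F)cc2)CCN1c1cccnc1`, > 25000 nM.

Each of these three values is a limit of this assay, not a number. Compound 3 therefore stands at the limit, with no number to separate it from the others. The chain extension from compound 1 to compound 2 reads a step that the two limits leave unreadable from compound 1 to compound 2, the halogen exchange from compound 1 to compound 3 reads a step that the two limits leave unreadable from compound 1 to compound 3, and the combined change from compound 2 to compound 3 reads a step that the two limits leave unreadable from compound 2 to compound 3; none gives a readable size, because of the limit of > 25000 nM in this assay, at which 3 of the 3 values shown sit.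

Compound 4, `O=C1N(CCCCCCOc2ccc(Br)cc2)CCN1c1cccnc1`, differs from compound 3 by bromo in place of fluoro on an aromatic carbon. For the measured compounds named here, the only halogen step measured, from compound 1 to compound 3, sat at the limit on both sides, so no direction can be read for a further halogen change; no step beyond the scatter is expected in this assay. Compound 4 is therefore expected to give 30000 nM, within 12000 nM to 100000 nM, most likely reported again as a limit. The expected step from compound 3 to compound 4 is a step that the limit leaves unreadable from compound 3 to compound 4.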

Compound 4, half-maximal cytotoxic concentration: > 25000 nM
Compound 4 gave a limit, no number; the forecaster's own chance of this, stated with the estimate: 85%; the middle value is on the limit's open side.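

No new step can be read between compound 4 and compounds 1, 2 and 3, because all four values are limits, not numbers: the limit of > 25000 nM in this assay, at which 4 of the 4 values shown sit.

The compounds shown leave open whether exchanging the halogen or extending the chain changes cytotoxicity at all.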